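Bromo for chloro in a mouse whole-organism series

A few compounds are considered here, and "the series" means these few. Any claim that something is new, unique, unknown or untested is made for them only; others in the source may bear on it.

The measured compounds:
compound 1, `O=C1CC(c2ccccc2Cl)n2ncnc2N1`, giving 25.5 mg/kg in a functional assay on the whole organism (strain Kunming) with Mus musculus as the target; a lower number here means that less compound is needed, a higher number that more compound is needed for the effect;
compound 2, `O=C1CC(c2cccc(Cl)c2)n2ncnc2N1`, giving 47.3 mg/kg in this assay;
compound 3, `O=C1CC(c2ccccc2Br)n2ncnc2N1`, giving 19.7 mg/kg in this assay.

Compounds 1 and 3 share one core. Compound 3 differs from compound 1 by bromo in place of chloro on an aromatic carbon, and the step this made was a 1.3-fold lower number from compound 1 to compound 3 (0.11 log units; within the scatter). Compound 2 is built from the same atoms as compound 1, joined differently; the difference between the two cores is not broken down here. Among the three numbers, compound 2 stands highest, with compound 1 nearest and compound 3 furthest from it.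

Compound 4, `O=C1CC(c2cccc(Br)c2)n2ncnc2N1`, has not yet been measured. It differs from compound 2 by bromo in place of chloro on an aromatic carbon. This is the same kind of change as that from compound 1 to compound 3, but the place is not the same: in compound 4 the bromo sits meta to a large group, while in compound 3 it sits ortho to a large group.

For the measured compounds named here, the only guide is the step from compound 1 to compound 3, which stayed within the scatter. On that basis the step from compound 2 to compound 4 in this assay is expected to be a 1.2-fold lower number from compound 2 to compound 4 (0.07 log units; within the scatter), resting on compound 2 giving 47.3 mg/kg and the step of a 1.3-fold lower number from compound 1 to compound 3 (0.11 log units; within the scatter). For compound 4 the estimate is 40 mg/kg, with a range from 20 mg/kg to 80 mg/kg.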

Compound 4, dose for half-maximal effect: 84.9 mg/kg
For compound 4 the middle estimate is 2.1-fold (0.33 log units) below the measured one, outside the stated range (above it).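

In this assay, putting bromo in place of chloro on the aromatic carbon meta to a large group gives a 1.8-fold higher number from compound 2 to compound 4 (0.25 log units; within the scatter), so this step, like the earlier one, stays inside the usual scatter of repeated measurements. Set side by side, the two steps point in opposite directions on paper, but the gap between them is no larger than two such steps can show by chance: the same change on two cores in this assay, a 1.3-fold lower number (0.11 log units; within the scatter) from compound 1 to compound 3 and a 1.8-fold higher number (0.25 log units; within the scatter) from compound 2 to compound 4, 2.3-fold (0.37 log units) apart, within the scatter of two such steps. For the compounds shown here, this shows that on these two cores the change produced no step that can be told from the scatter and no firm difference between the cores, but it does not show that the change carries over reliably, since it rests on just two pairs, and a change that moved the number little on both cores gives no real effect to follow from one to the other.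

The compounds shown leave open whether a fluoro, a methoxy, an amine or a carboxylic acid on the same aromatic ring would move the number in this assay beyond the scatter. They also leave open how bromo in place of chloro would behave at any other place on that ring, or on a core carrying a methyl group in place of the amide hydrogen.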